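The source may report more compounds than this note shows. Statements on the series, on what has been measured and on what is new or still open speak of the compounds shown alone.

Measured compounds:
compound 1, `CCCCCCCCCCCCCCNC(=O)[C@H](CO)/N=C/c1cccc(OC)c1`, which in a functional assay on cells (Homo sapiens) for cytotoxicity, read by MTT assay, with a stated time of 24 h (a lower number here means a stronger inhibitor, a higher number a weaker inhibitor), gives 31300 nM
compound 2, `CCCCCCCCCCCCCCNC(=O)[C@H](CO)/N=C/c1ccc(OC)cc1`, which in this assay gives 28100 nM
compound 3, `CCCCCCCCCCCCCCNC(=O)[C@H](CO)/N=C/c1ccccc1Cl`, which in this assay gives 10300 nM

Compound 2 stands second highest of the three numbers. Its nearest neighbour is compound 1, with a 1.1-fold lower number from compound 1 to compound 2 (0.05 log units; within the scatter); its furthest is compound 3, with a 2.7-fold lower number from compound 2 to compound 3 (0.44 log units; beyond the scatter). The three measured compounds share one core and differ only in the aryl group on the carbon with a double bond to nitrogen.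

The step from compound 2 to compound 4, `CCCCCCCCCCCCCCNC(=O)[C@H](CO)/N=C/c1ccc(O)cc1`, is a different kind of change: hydrogen in place of methyl on an oxygen on an aromatic ring. Within the data shown here, none of the measured steps alters this position in this way. Among the measured compounds shown here, the one step that stays within the scatter, a 1.1-fold lower number from compound 1 to compound 2 (0.05 log units; within the scatter), moves a methoxy group from one ring position to another; the two steps beyond the scatter, a 3.0-fold lower number from compound 1 to compound 3 (0.48 log units; beyond the scatter) and a 2.7-fold lower number from compound 2 to compound 3 (0.44 log units; beyond the scatter), exchange a methoxyphenyl for a 2-chlorophenyl and are modest. Nothing measured speaks directly to removing the methyl from the oxygen, so the expectation for this assay is a step from compound 2 to compound 4 of no more than modest size, in either direction, with the most likely outcome no step beyond the scatter.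

Compound 4 is therefore estimated at 30000 nM, within a range from 12000 nM to 70000 nM, which amounts to an expected step of a 1.1-fold higher number from compound 2 to compound 4 (0.03 log units; within the scatter).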

Compound 4, half-maximal inhibitory concentration: 19300 nM
The estimate for compound 4 lay 1.6-fold (0.19 log units) above the measured number; the range from low to high includes it.
By their numbers in this assay, from the lowest: compounds 3, 4, 2 and 1 (each within the scatter of the next, the first and the last beyond it).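

In this assay, among these compounds, taking the methyl off the oxygen on the aromatic ring, methoxy to hydroxy, gives a 1.5-fold lower number from compound 2 to compound 4 (0.16 log units; within the scatter) and so adds a kind of change that no earlier step had tested, one that here stays inside the scatter. The 4-hydroxyphenyl group also does not separate from either of the other two aryl groups, with a 1.6-fold lower number from compound 1 to compound 4 (0.21 log units; within the scatter) and with a 1.9-fold higher number from compound 3 to compound 4 (0.27 log units; within the scatter) as the two further steps, so compound 4 falls within the scatter of compound 1 and of compound 3, although those two lie beyond the scatter of each other. No measurement offered here accounts for this result or bears on it.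

What the compounds shown leave open is whether a larger group on that oxygen, such as an ethyl ether or an acetate ester, or an amine or a carboxylic acid in place of the hydroxy group, would produce a step beyond the scatter. Also open, as far as these compounds go, is whether a shorter chain in place of the long alkyl chain shared by all four compounds would change these numbers.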